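The source may report more compounds than this note shows. Statements on the series, on what has been measured and on what is new or still open speak of the compounds shown alone.

Of the compounds shown here, two of this set have been measured. Compound 1 `CC(=O)Oc1ccc(/C=C/C(=O)OCCSc2nc(-c3ccc(S(C)(=O)=O)cc3)n(-c3ccc(F)cc3)n2)cc1OC(C)=O` gives 1050 nM in an assay on cells (strain Sprague-Dawley) for inhibition of Polyunsaturated fatty acid 5-lipoxygenase (Rattus norvegicus), with a stated time of 30 min; a lower number here means a stronger inhibitor, a higher number a weaker inhibitor. Compound 2 `COc1cc(/C=C/C(=O)OCCSc2nc(-c3ccc(S(C)(=O)=O)cc3)n(-c3ccc(Br)cc3)n2)ccc1OC(C)=O` gives 940 nM in this assay. Compound 2 carries the lower of the two numbers, yet the gap to compound 1 lies within the scatter of the measurement, so the two cannot be told apart on these data. Compound 3 `COc1cc(/C=C/C(=O)OCCSc2nc(-c3ccc(S(C)(=O)=O)cc3)n(-c3ccc(F)cc3)n2)ccc1OC(C)=O` has not yet been measured. It differs from compound 2 in one place: fluoro in place of bromo on an aromatic carbon. Going by the values given here, no measured pair in the set shows this same change, so nothing in the data fixes its size. The closest point of comparison is compound 1, which also carries the fluoro group and gives 1050 nM, a number that sits beside that of compound 2 within the scatter. The expectation for compound 3 in this assay is therefore a step of no consequence beyond the scatter, in either direction, a 1.1-fold higher number from compound 2 to compound 3 (0.03 log units; within the scatter). Compound 3 is expected to give 1000 nM, within a range from 500 nM to 2000 nM.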

Compound 3, half-maximal inhibitory concentration: 920 nM
Estimate against measurement, compound 3: 1.1-fold (0.04 log units) above; measured number inside the range.
By their numbers in this assay, from the lowest: compounds 3, 2 and 1 (each within the scatter of the next).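

In this assay, the change from 4-bromophenyl to 4-fluorophenyl now has a measured size, a 1.0-fold lower number from compound 2 to compound 3 (0.01 log units; within the scatter), so on this aromatic carbon, para to a large group, bromo and fluoro cannot be told apart. The new compound also gives the set its first reading at a second place, on the oxygen on an aromatic ring, where methyl stands in place of acetyl: a 1.1-fold lower number from compound 1 to compound 3 (0.06 log units; within the scatter), likewise a step that does not rise above the scatter. No further measurement bears on either step, so the data offer no account of what lies behind these numbers.

Each change rests on a single pair, so neither can be carried over to another compound, and the compounds shown leave open whether an amine or a carboxylic acid in place of the halogen, or a free hydroxyl in place of the methoxy group, would give a step beyond the scatter. As far as these compounds go, all three compounds also keep the methylsulfonyl group and the shared core unchanged, so what a sulfonamide at that place or a longer chain in the ester would do remains unknown.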